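Azole replacement on the shared core, paw edema series

A few compounds are considered here, and "the series" means these few. Any claim that something is new, unique, unknown or untested is made for them only; others in the source may bear on it.

Compound 1 `O=C(O)c1cc(-c2c[nH]cn2)ccc1O` gives 100 mg/kg in a functional assay on the whole organism for inhibition, with Rattus norvegicus as the target, read by paw edema (a lower number here means that less compound is needed, a higher number that more compound is needed for the effect), the second highest of three numbers in this series. Compound 3 `O=C(O)c1cc(-c2ccccn2)ccc1O` gives 200 mg/kg, which lies within the scatter of compound 1. Compound 2 `CC(=O)Oc1ccc(-n2cccc2)cc1C(=O)O` gives 42 mg/kg, a lower number beyond the scatter. Compound 4 `O=C(O)c1cc(-n2cccn2)ccc1O` is not yet measured; it differs from compound 1 as follows: 1H-pyrazol-1-yl in place of 1H-imidazol-4-yl on an aromatic carbon. For the measured compounds named here, no pair of measured compounds isolates this change, so no direct comparison exists. Compound 2 differs from compound 1 in more than one place, so its lower number cannot be tied to the ring change alone. The step of no change at the digits printed from compound 1 to compound 4 (within the scatter) is expected to be small, in either direction, and probably within the scatter. Compound 4 is expected to give 100 mg/kg, with a range from 40 mg/kg to 250 mg/kg.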

Compound 4, dose for half-maximal effect: 200 mg/kg
Compound 4: middle estimate off by 2.0-fold (0.30 log units), on the low side, within the range that was stated.
By their numbers in this assay, from the lowest: compound 2; then compounds 1, 3 and 4 (each within the scatter of the next).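

In this assay, for the compounds shown here, 1H-pyrazol-1-yl in place of 1H-imidazol-4-yl gives a 2.0-fold higher number from compound 1 to compound 4 (0.30 log units; within the scatter), the first direct reading of a ring change at this place, meta to the carboxy group and para to the hydroxy group. 1H-imidazol-4-yl has a hydrogen-bond donor and 1H-pyrazol-1-yl has none, yet the two compounds lie within the scatter of each other. No measurement at hand offers a reason for this result.

The lower number of compound 2 stays unassigned to any one of its differences. On these data alone, whether an amine or a longer chain in this place would reach beyond the scatter of compound 1 remains open.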